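Sulfoxide to Sulfone: Expected Cytotoxicity of Compound 4

The source may hold more compounds than are shown below. What is called first, only, known or untested is meant among the compounds shown, and "the series" means these compounds.

Compound 1 `COc1ccc(S(=O)(=O)N(CC(N)=O)c2ccc(N(CC(N)=O)S(=O)(=O)c3ccc(SCCCCN=C=S)cc3)c3ccccc23)cc1`, compound 2 `COc1ccc(S(=O)(=O)N(CC(N)=O)c2ccc(N(CC(N)=O)S(=O)(=O)c3ccc(SCCOCCOCCN=C=S)cc3)c3ccccc23)cc1` and compound 3 `COc1ccc(S(=O)(=O)N(CC(N)=O)c2ccc(N(CC(N)=O)S(=O)(=O)c3ccc([S+]([O-])CCCCCN=C=S)cc3)c3ccccc23)cc1` share one core and were tested in an ADME assay on cells (Peritoneal macrophage, Mus musculus) for cytotoxicity, read by CCK-8 assay, with a stated time of 24 h; on this read-out lower numbers stand for higher toxicity in this test and higher numbers for lower toxicity in this test. Compound 1 reaches only the limit of the assay, > 10000 nM. Compound 2 likewise gives a limit, > 10000 nM. Compound 3 also stands at a limit, > 10000 nM. The steps a step that the two limits leave unreadable from compound 1 to compound 2, a step that the two limits leave unreadable from compound 1 to compound 3 and a step that the two limits leave unreadable from compound 2 to compound 3 carry no readable size, because of the limit of > 10000 nM in this assay, at which 3 of the 3 values shown sit. Compound 4 `COc1ccc(S(=O)(=O)N(CC(N)=O)c2ccc(N(CC(N)=O)S(=O)(=O)c3ccc(S(=O)(=O)CCCCCN=C=S)cc3)c3ccccc23)cc1` differs from compound 3 by a group of 11 heavy atoms (6 carbon, 1 nitrogen, 2 oxygen, 2 sulfur; no ring) in place of a group of 10 heavy atoms (6 carbon, 1 nitrogen, 1 oxygen, 2 sulfur; no ring), on an aromatic carbon. The three unreadable steps are the only measured ones that bear on this change, so compound 4 is expected to show a step that the limit leaves unreadable from compound 3 to compound 4 in this assay, none readable beyond the scatter. Compound 4 is therefore estimated at 15000 nM, within a range from 8000 nM to 40000 nM, most probably reported again only as a limit.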

Compound 4, half-maximal cytotoxic concentration: > 10000 nM
Compound 4: a limit, no number; the forecaster's own chance of this, stated with the estimate: 85%; the middle value is on the limit's open side.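

The steps from compound 1, compound 2 and compound 3 to compound 4 cannot be read in this assay, because each compound gives only a limit: the limit of > 10000 nM in this assay, at which 4 of the 4 values shown sit.

The compounds shown leave open what half-maximal cytotoxic concentration any of them has, and whether the exchanged groups differ at all in this test.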